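The source may hold more compounds than are shown below. What is called first, only, known or untested is meant among the compounds shown, and "the series" means these compounds.

Compound 1: `CN1CCN(c2ccc(Nc3cnccc3/C=C/C(N)=O)cc2)CC1` — 75%
Compound 2: `CNC(=O)/C=C/c1ccncc1-c1ccc2cnn(C)c2c1` — 99%

Of the compounds shown here, two have been measured in an assay on a protein complex for inhibition of CDK8/Cyclin C (Homo sapiens), with a stated time of 1 h, tested at 10 uM; on this read-out lower numbers stand for less inhibition and higher numbers for more inhibition at the one concentration tested (going by the name of the read-out). Compound 1 gives 75% in this assay, while compound 2 gives 99%. Compound 2 therefore stands highest of the two numbers, and the gap to compound 1 is beyond the usual scatter of repeated measurements, so the inhibition of compound 2 in this assay is the higher of the pair. The two structures differ in several places at once, so no single change can be read from them.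

The next compound, compound 3 `Cn1ncc2ccc(-c3cnccc3/C=C/C(=O)N3CCOCC3)cc21`, keeps the whole of compound 2 except at one point: morpholin-4-yl in place of methylamino on a carbonyl carbon. The amide hydrogen of compound 2 is lost and a six-membered non-aromatic ring enters on the carbonyl carbon. Because compound 2 already reaches 99%, there is little room for a rise; the step from compound 2 to compound 3 is expected to be small and downward, or none beyond the scatter. For compound 3 the estimated value in this assay is 92%, with an expected range of 75% to 100%, which means an expected step of a number 7 percentage points lower from compound 2 to compound 3 (within the scatter).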

Compound 3, a percentage reported as inhibition, at one concentration (the size of the read-out at that concentration, not a potency): 89%
For compound 3 the middle estimate is 3 percentage points above the measured one; measured number inside the range.
By their numbers in this assay, from the lowest: compound 1; then compounds 3 and 2 (each within the scatter of the next).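

In this assay, for the compounds shown here, the exchange of methylamino for morpholin-4-yl on the carbonyl carbon gives a number 10 percentage points lower from compound 2 to compound 3 (within the scatter) and is the first comparison here that changes only one place. The exchange removes the amide hydrogen of compound 2 and brings in a six-membered non-aromatic ring with 2 hetero atoms, and the result shows that a high reading at this one concentration can be kept without that hydrogen and with the ring in place. Nothing measured here explains this outcome.

A percentage at one concentration is not a potency, and with compound 2 at 99% and compound 3 at 89% near the top of the scale, any difference in potency between the two may stay hidden. Going by these compounds alone, the single step also changes the hydrogen, the ring and the ring oxygen together, so it remains open how other groups on the same carbonyl carbon would read, such as dimethylamino, which lacks the amide hydrogen but has no ring, piperidin-1-yl, which has a ring without the oxygen, or a carboxylic acid.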